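A Second Hydroxy Added to the Weakest Analogue

This account rests on a few compounds, and the source may have more. Where it says the series, first, only, none or still open, it means among the compounds named here.

Compound 1, `C/C(=N\NC(=O)c1cccc(S(=O)(=O)N2CCOCC2)c1)c1ccc(F)cc1`: > 100000 nM
Compound 2, `C/C(=N\NC(=O)c1cccc(S(=O)(=O)N2CCOCC2)c1)c1ccccc1O`: 5450 nM
Compound 3, `C/C(=N\NC(=O)c1cccc(S(=O)(=O)N2CCOCC2)c1)c1cccc(O)c1`: > 100000 nM

In a functional assay on ECa-109 cells for antiproliferative activity against ECa-109 cell line (Homo sapiens), read by MTT assay, with a stated time of 72 h (on this read-out higher numbers stand for weaker inhibition and lower numbers for stronger inhibition), compound 3 sits at a limit, (the limit of > 100000 nM in this assay, at which 2 of the 3 values shown sit), so no number is known for it. Compound 4, `C/C(=N\NC(=O)c1cccc(S(=O)(=O)N2CCOCC2)c1)c1cc(O)ccc1O`, differs from compound 3 by hydroxy in place of hydrogen on an aromatic carbon. For the measured compounds named here, two measured steps bear on this: an at least 18-fold lower number from compound 1 to compound 2 (1.26 log units; beyond the scatter), and an at least 18-fold higher number from compound 2 to compound 3 (1.26 log units; beyond the scatter); the step that the two limits leave unreadable from compound 1 to compound 3 cannot be read. Compound 4 carries the 2-hydroxy arrangement of compound 2, so a number near compound 2 is expected, meaning a large drop from the limit of compound 3 in this assay. Compound 4 is estimated at 8000 nM, between 2000 nM and 60000 nM. This estimate corresponds to an expected step of an at least 12-fold lower number from compound 3 to compound 4 (1.09 log units; beyond the scatter).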

Compound 4, half-maximal inhibitory concentration: 21400 nM
Compound 4: the middle estimate sits 2.7-fold (0.43 log units) below what was measured; the measured number falls inside the stated range.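

A hydroxy placed ortho to the large group restores measurable activity to the 3-hydroxyphenyl compound, giving an at least 4.6-fold lower number from compound 3 to compound 4 (0.66 log units; beyond the scatter), and replacing 4-fluorophenyl with 2,5-dihydroxyphenyl gives an at least 4.6-fold lower number from compound 1 to compound 4 (0.66 log units; beyond the scatter). Compound 1 and compound 3 each sit at a limit, not a number, so these two steps give only minimum sizes: the limit of > 100000 nM in this assay, at which 2 of the 4 values shown sit. The second hydroxy does not add to the activity of the 2-hydroxyphenyl group, giving instead a 3.9-fold higher number from compound 2 to compound 4 (0.59 log units; beyond the scatter). As far as these compounds go, whether an amine or a methoxy group in that place would also restore activity remains open.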